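The source may hold more compounds than are shown below. What is called first, only, known or untested is meant among the compounds shown, and "the series" means these compounds.

In a functional assay on A549 cells (Homo sapiens) for inhibition, read by MTT assay, with a stated time of 48 h (on this read-out higher numbers stand for weaker inhibition of growth and lower numbers for stronger inhibition of growth), three compounds that share the same core have been measured so far. Compound 1 (`Cn1cc(C2CC(c3ccccc3)=NN2C(=O)c2ccncc2)c2ccccc21`) gives 990 nM, compound 2 (`COc1cc(C2=NN(C(=O)c3ccc(C)nc3)C(c3cn(C)c4ccccc34)C2)cc(OC)c1OC`) gives 230 nM, and compound 3 (`Cn1cc(C2CC(c3ccccc3)=NN2C(=O)c2cccnc2)c2cc(Br)ccc21`) gives 1600 nM. Compounds 1 and 3 form the upper end of these numbers and lie within the scatter of each other, so they cannot be ranked. Compound 2 is the only one set clearly apart, with a lower number than compound 3 by a margin beyond the scatter.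

The next compound, compound 4 (`Cn1cc(C2CC(c3ccc(Br)cc3)=NN2C(=O)c2cccnc2)c2cc(Br)ccc21`), is compound 3 with one small edit: phenyl becomes 4-bromophenyl, a bromo in place of hydrogen on an aromatic carbon. For the measured compounds named here, no two measured compounds differ in only one place, so nothing here shows directly what this edit does in this assay. The three measured compounds also differ from one another in several places at once, which leaves no basis for predicting a direction with confidence. The expectation is therefore a modest one, with no change beyond the scatter: the estimated change is a 1.2-fold lower number from compound 3 to compound 4 (0.09 log units; within the scatter). For compound 4 the expected value is 1300 nM, with an estimated range from 450 nM to 3800 nM.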

Compound 4, concentration for 50% growth inhibition: > 10000 nM
Compound 4 was reported as a limit (the forecaster's own chance of this, stated with the estimate: 5%); middle value at least 7.6-fold (0.88 log units) from the limit.
By their numbers in this assay, from the lowest: compound 2; then compounds 1 and 3 (each within the scatter of the next). At a limit, above all of these: compound 4.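

For the compounds shown here, this is the first step here that changes a single place, and it shows that the place on an aromatic carbon of the six-membered aromatic ring of carbon only, para to a large group, matters in this assay: going from phenyl to 4-bromophenyl gives an at least 6.2-fold higher number from compound 3 to compound 4 (0.79 log units; beyond the scatter) on this read-out. Going by these compounds alone, the change points towards weaker inhibition of growth and lies beyond the scatter, something the earlier compounds could not show, as they differ from one another in several places at once. Compound 4 stands as > 10000 nM in a sentence of its own because that value is a limit and not a number, so the step has a floor but no known full size: the limit of > 10000 nM in this assay, at which 1 of the 4 values shown sits.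

The compounds shown leave open whether this outcome belongs to bromo in particular or would also follow from another group at the same carbon, such as fluoro, a small atom, or an amine. They also leave open whether the same edit would act in the same direction on compound 1, whose core carries no bromo.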